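Cyclobutyl to tert-Butyl on the Shared Core

The source may report more compounds than this note shows. Statements on the series, on what has been measured and on what is new or still open speak of the compounds shown alone.

Compound 1 `O=C(O)CCNC(=O)c1ccc(C(Oc2ccc(-n3cc(C(F)(F)F)cn3)cc2)C2CCC2)cc1` gives 3000 nM in a functional assay on cells for antagonist activity at Glucagon receptor (Homo sapiens), read by cAMP accumulation, in the presence of a further agent that is not named here; a higher number here means a weaker inhibitor, a lower number a stronger inhibitor.
Compound 2 `CCCC(Oc1ccc(-n2cc(C#N)cn2)cc1)c1ccc(C(=O)NCCC(=O)O)cc1` gives > 50000 nM in this assay, which is a limit of the assay and not a number.
Compound 3 `CCCC(Oc1ccc(-n2cc3c(n2)CCCC3)cc1)c1ccc(C(=O)NCCC(=O)O)cc1` gives 4200 nM in this assay.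

Of the two numbers shown, compound 1 has the lowest, with compound 3 within the usual scatter of it. Compound 2 sits at the limit of > 50000 nM in this assay, at which 1 of the 3 values shown sits.

Compound 4 `CC(C)(C)C(Oc1ccc(-n2cc(C(F)(F)F)cn2)cc1)c1ccc(C(=O)NCCC(=O)O)cc1` differs from compound 1 by tert-butyl in place of cyclobutyl on a saturated chain carbon bound to an aromatic carbon and an oxygen on an aromatic ring. Among the measured compounds shown here, the only measured step, an at least 11-fold lower number from compound 2 to compound 3 (1.07 log units; beyond the scatter), alters a group on an aromatic carbon elsewhere on the shared core, so it does not bear on this swap. For the measured compounds named here, no measured step touches the place changed here, so the expectation for compound 4 rests on compound 1 alone, and no step beyond the scatter is expected: no change at the digits printed from compound 1 to compound 4 (within the scatter). Compound 4 is therefore estimated at 3000 nM, with a range from 1000 nM to 10000 nM.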

Compound 4, antagonist equilibrium constant: 4300 nM
Compound 4: the middle estimate sits 1.4-fold (0.16 log units) below what was measured; the measured number falls inside the stated range.
By their numbers in this assay, from the lowest: compounds 1, 3 and 4 (each within the scatter of the next). At a limit, above all of these: compound 2.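

At this position, on a saturated chain carbon bound to an aromatic carbon and an oxygen on an aromatic ring, the step is a 1.4-fold higher number from compound 1 to compound 4 (0.16 log units; within the scatter) in this assay. So the four-membered ring of cyclobutyl can give way to the ringless tert-butyl, with the same count of heavy atoms, without a change beyond the scatter. Nothing measured here accounts for this result.

From the compounds shown here alone, it remains open whether this position also accepts a much smaller group such as methyl, or one carrying an amine or a hydroxyl group.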